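Amide-linked variation on the shared core: compound 4

A few compounds are considered here, and "the series" means these few. Any claim that something is new, unique, unknown or untested is made for them only; others in the source may bear on it.

Compound 1 `COc1cc2nc(N3CCN(C(=O)/C=C/c4cccc(F)c4)CC3)nc(N)c2cc1OC` is measured in an assay for binding affinity to Adrenergic receptor alpha-1 (Rattus norvegicus) (on this read-out lower numbers stand for stronger inhibition and higher numbers for weaker inhibition), at 20.9 nM. Among the three measured compounds it stands second highest: compound 2 `COc1cc2nc(N3CCN(/C(S)=N/C4CCCCC4)CC3)nc(N)c2cc1OC` gives 5.37 nM, compound 3 `COc1cc2nc(N3CCN(/C(S)=N/c4ccc(NC(=S)N5CC5)cc4)CC3)nc(N)c2cc1OC` gives 97.7 nM. For the measured compounds named here, the only measured step, an 18-fold higher number from compound 2 to compound 3 (1.26 log units; beyond the scatter), concerns the substituent on a double-bonded nitrogen, not the carbonyl side. Compound 4 `COc1cc2nc(N3CCN(C(=O)c4ccc(N=C=S)c(I)c4)CC3)nc(N)c2cc1OC` differs from compound 1 by a group of 10 heavy atoms (7 carbon, 1 nitrogen, 1 sulfur, 1 iodine; one six-membered aromatic ring of carbon only) in place of a group of 9 heavy atoms (8 carbon, 1 fluorine; one six-membered aromatic ring of carbon only), on a carbonyl carbon. Going by the values given here, no measured step bears directly on this change; the gap between compound 1 and compound 2 and the step from compound 2 to compound 3 both show that the series spans a wide range, so a moderate shift in either direction in this assay is expected, estimated as a 1.4-fold higher number from compound 1 to compound 4 (0.16 log units; within the scatter). For compound 4 a value of 30 nM is expected, within 8 nM to 120 nM.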

Compound 4, half-maximal inhibitory concentration: 51.3 nM
Beside the measured number, compound 4's estimate is 1.7-fold (0.23 log units) below it; low and high end bracket the measured number.
By their numbers in this assay, from the lowest: compound 2; then compound 1; then compounds 4 and 3 (each within the scatter of the next).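

In this assay the carbonyl carbon now has its first reading of a group change: replacing 2-(3-fluorophenyl)ethenyl with the aromatic group carrying iodine, nitrogen and sulfur gives a 2.5-fold higher number from compound 1 to compound 4 (0.39 log units; beyond the scatter). This modest step shows that the carbonyl side responds to the group it bears, with the entering group losing the 2-(3-fluorophenyl)ethenyl double bond and chain. No available evidence accounts for the shift. Going by these compounds, the iodine and the nitrogen-sulfur part enter together, so their separate shares remain open. On these data alone, how an unsubstituted phenyl or an amine-bearing phenyl would read at this carbonyl carbon also remains open.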